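Benzylamide in place of anilide on the shared core

A few compounds are considered here, and "the series" means these few. Any claim that something is new, unique, unknown or untested is made for them only; others in the source may bear on it.

The series shares the core of compound 1 `O=C(CCSc1nnc(-c2ccncc2)s1)Nc1ccccc1`; compound 2 `CC(Sc1nnc(-c2ccncc2)s1)C(=O)Nc1ccc(Cl)cc1` and compound 3 `CC(CSc1nnc(-c2ccncc2)s1)C(=O)Nc1ccc(Cl)cc1` carry the same core with different linkers and anilides. In an ADME assay on BHK-21 cells (Mesocricetus auratus) for cytotoxicity, with a stated time of 3 days (a lower number here means that less compound is tolerated, a higher number that more compound is tolerated), compound 1 gives > 50000 nM, which is a limit of the assay and not a number. Compound 2 likewise reaches only > 50000 nM, a limit. Compound 3 also sits at > 50000 nM, a limit. Going by the values given here, no step between measured compounds can be given; what the measurements show is the limit of > 50000 nM in this assay, at which 3 of the 3 values shown sit. Compound 4 `O=C(CCSc1nnc(-c2ccncc2)s1)NCc1ccccc1` differs from compound 1 by benzyl in place of phenyl on an amide-type nitrogen, anilino to benzylamino. With every measured compound at the limit, the expected step in this assay is a step that the limit leaves unreadable from compound 1 to compound 4, none beyond the scatter. Compound 4 is accordingly expected at 60000 nM, between 20000 nM and 200000 nM, most likely again reported only as a limit.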

Compound 4, half-maximal cytotoxic concentration: 18700 nM
The estimate for compound 4 lay 3.2-fold (0.51 log units) above the measured number; the measured number lies below the stated range.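

In this assay, benzyl in place of phenyl on an amide-type nitrogen gives an at least 2.6-fold lower number from compound 1 to compound 4 (0.42 log units; beyond the scatter), so the group at this nitrogen can move the read-out. This step is a lower bound, and its full size cannot be read. Compound 4 is the only compound shown with a readable number: the limit of > 50000 nM in this assay, at which 3 of the 4 values shown sit.

On these data alone, whether phenethyl, a longer chain, on the same nitrogen lowers the number further remains open, as does whether chlorobenzyl or pyridylmethyl behaves like benzyl. Also open, as far as these compounds go, is whether the benzylamide has the same effect on the linkers of compound 2 and compound 3.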